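Methoxy in place of methylsulfanyl: an expected small step

The source may report more compounds than this note shows. Statements on the series, on what has been measured and on what is new or still open speak of the compounds shown alone.

Measured so far:
compound 1 `CSc1ccc(CNc2nc(SC)nc3ncccc23)cc1`: 3770 nM
compound 2 `CSc1nc(NCCCc2ccccc2)c2ccccc2n1`: > 100000 nM

For the measured compounds named here, in an ADME assay on BEAS-2B cells (Homo sapiens) for cytotoxicity, read by MTT assay, with a stated time of 72 h (on this read-out higher numbers stand for weaker inhibition of growth and lower numbers for stronger inhibition of growth), compound 1 gives 3770 nM, the only actual number among the two results. Compound 2 gives > 100000 nM, which is a limit of the assay and not a number. Of the two values shown, (the limit of > 100000 nM in this assay, at which 1 of the 2 values shown sits).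

Compound 3 `COc1ccc(CNc2nc(SC)nc3ncccc23)cc1` differs from compound 1 by methoxy in place of methylsulfanyl on an aromatic carbon. Going by the values given here, no measured pair shows this change, so no step beyond the usual scatter is expected in this assay. Compound 3 is therefore estimated at 5000 nM, within 1500 nM to 20000 nM. The expected step is a 1.3-fold higher number from compound 1 to compound 3 (0.12 log units; within the scatter).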

Compound 3, concentration for total growth inhibition: > 100000 nM
Compound 3: a limit, no number; the forecaster's own chance of this, stated with the estimate: 15%; middle value at least 20-fold (1.30 log units) from the limit.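

In this assay, replacing methylsulfanyl with methoxy on this aromatic carbon, para to a large group, is no small change: the step is an at least 26-fold higher number from compound 1 to compound 3 (1.42 log units; beyond the scatter). Both groups have the same count of heavy atoms, so that count alone does not tell them apart here. The result for compound 3 is a limit of the assay and not a number, so the true size of the step stays unknown, and such limits make up most of the results: the limit of > 100000 nM in this assay, at which 2 of the 3 values shown sit.

Going by these compounds, it remains open whether a chloro group or an amine at this position would give a measurable number. Compound 2 differs from compound 1 in more than one place, so it cannot settle this.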